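From acetyl to hydrogen on the ring oxygen

The compounds below may be only part of what the source reports. "The series", "measured", "known", "first", "only" and "open" are said of these compounds alone.

Three compounds here share one core. Compound 1 `CCOc1cccc2cc(-c3ccccc3)c(=O)oc12` gives 22100 nM in an assay on CHO cells for displacement of a labelled ligand from adenosine receptor A1 (Homo sapiens), read by radioligand binding; a lower number here means a stronger inhibitor, a higher number a weaker inhibitor. Compound 2 `O=c1oc2c(O)cccc2cc1-c1ccc(Br)cc1` reaches only a limit of this assay, > 100000 nM. Compound 3 `CC(=O)Oc1cccc2cc(-c3ccccc3)c(=O)oc12` gives 6930 nM in this assay, the lowest of the two numbers, set apart from compound 1 by the step of a 3.2-fold lower number from compound 1 to compound 3 (0.50 log units; beyond the scatter). Compound 4 `O=c1oc2c(O)cccc2cc1-c1ccccc1` differs from compound 3 by hydrogen in place of acetyl on an oxygen on an aromatic ring. Within the data shown here, no measured step covers this exact change; the one measured step shows that the acetyl itself helped, and compound 2, which also carries hydroxy rather than acetoxy together with a bromine, sits at the limit. A loss is therefore expected, with the step estimated as a 4.3-fold higher number from compound 3 to compound 4 (0.64 log units; beyond the scatter). Compound 4 is estimated at 30000 nM, between 8000 nM and 100000 nM.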

Compound 4, inhibition constant: 4620 nM
The estimate for compound 4 lay 6.5-fold (0.81 log units) above the measured number; the whole stated range lies above it.
By their numbers in this assay, from the lowest: compounds 4 and 3 (each within the scatter of the next); then compound 1. At a limit, above all of these: compound 2.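

In this assay, hydrogen and acetyl on this oxygen read alike (a 1.5-fold lower number from compound 3 to compound 4 (0.18 log units; within the scatter)), while hydrogen still gives a lower number than ethyl (a 4.8-fold lower number from compound 1 to compound 4 (0.68 log units; beyond the scatter)). So the free hydroxy is no handicap, and the bromo on an aromatic carbon is what now separates compound 2 from compound 4 (an at least 21-fold lower number from compound 2 to compound 4 (1.33 log units; beyond the scatter)). The reading for compound 2 is a limit of the assay, not a number: (the limit of > 100000 nM in this assay, at which 1 of the 4 values shown sits).

The compounds shown leave open how a longer chain, or a chain ending in an amine, would read on this oxygen. Also open, from the compounds shown here alone, is whether chlorine or methoxy in place of the bromo would give the same result.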